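From Bromo to Methyl on the Shared Core

The source may report more compounds than this note shows. Statements on the series, on what has been measured and on what is new or still open speak of the compounds shown alone.

Among the compounds with values here, in a functional assay on NCI-H520 cells (Homo sapiens) for cytotoxicity (on this read-out lower numbers stand for stronger inhibition of growth and higher numbers for weaker inhibition of growth), compound 1 `COc1ccc(C2=C(c3ccc(SC)cc3)CC3CCCN3C2=O)cc1O` gives 6000 nM, while compound 2 `COc1ccc(C2=C(c3ccc(SC)cc3)CC3CCCN3C2=O)cc1Br` gives 700 nM, the lower of the two numbers so far. Compound 3 `COc1ccc(C2=C(c3ccc(SC)cc3)CC3CCCN3C2=O)cc1C` has not yet been measured. It differs from compound 2 by methyl in place of bromo on an aromatic carbon. Within the data shown here, only one measured step bears on this change: an 8.6-fold lower number from compound 1 to compound 2 (0.93 log units; beyond the scatter). That modest step, with bromo in place of hydroxy on the same carbon, shows that a swap here can move the number beyond the scatter. Among the measured compounds shown here, no measured compound carries methyl at this place, so the size of the new step remains uncertain. Starting from the value of compound 2, 700 nM, a small rise is expected, possibly within the scatter. The expected step is a 1.4-fold higher number from compound 2 to compound 3 (0.15 log units; within the scatter). For compound 3 the estimate is 1000 nM, with an expected range from 350 nM to 3000 nM.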

Compound 3, concentration for 50% growth inhibition: 100 nM
The estimate for compound 3 lay 10-fold (1.00 log units) above the measured number, and the stated range ends above it.
By their numbers in this assay, from the lowest: compound 3; then compound 2; then compound 1.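

In this assay, within the data shown here, methyl in place of bromo on this aromatic carbon gives a 7.0-fold lower number from compound 2 to compound 3 (0.85 log units; beyond the scatter), so the lowest number so far no longer belongs to the bromo compound. Methyl in place of hydroxy at the same place gives a 60-fold lower number from compound 1 to compound 3 (1.78 log units; beyond the scatter), and the three groups now fall in a clear order, from methyl with the lowest number through bromo to hydroxy with the highest, with every gap beyond the scatter. Nothing available explains why the groups fall in this order.

Three groups on one carbon cannot show whether a longer chain such as ethyl would lower the number further or raise it again. On these data alone, how an amine or a carboxylic acid at this place would compare with methyl also stays open.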